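Lengthening a Chain Without a Measured Number

A few compounds are considered here, and "the series" means these few. Any claim that something is new, unique, unknown or untested is made for them only; others in the source may bear on it.

In a functional assay on KB cells (Homo sapiens) for inhibition, read by CellTiter-Blue, with a stated time of 96 h (on this read-out lower numbers stand for stronger inhibition and higher numbers for weaker inhibition), compound 1 `Nc1nc2[nH]c(CCCCCCC(=O)N[C@@H](CCC(=O)O)C(=O)O)cc2c(=O)[nH]1` gives 7.9 nM. Compound 2 `Nc1nc2[nH]c(CCCCCC(=O)O)cc2c(=O)[nH]1` reports only a limit, > 1000 nM. From the compounds shown here alone, compound 3 `Nc1nc2[nH]c(CCCCCCC(=O)O)cc2c(=O)[nH]1` also reports only a limit, > 1000 nM, so its true value remains unknown. Among the compounds with values here, compound 1 is thus the only compound here with an actual number.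

The untested compound 4 `Nc1nc2[nH]c(CCCCCCCCC(=O)O)cc2c(=O)[nH]1` differs from compound 3 in its chain: 2-carboxyethyl in place of carboxy on a saturated chain carbon, six bonds along the chain from an aromatic carbon. In words, this is 2-carboxyethyl in place of carboxy on a saturated chain carbon, six bonds along the chain from an aromatic carbon.

Within the data shown here, one measured step bears on this change, since it also extends the chain: a step that the two limits leave unreadable from compound 2 to compound 3. Both of its ends rest on (the limit of > 1000 nM in this assay, at which 2 of the 3 values shown sit), so it offers no size to carry forward. Among the measured compounds shown here, with that step as the only guide, no gain beyond the usual scatter is expected in this assay, and the likeliest outcome is another limit rather than a number. The expected change is a step that the limit leaves unreadable from compound 3 to compound 4. For compound 4 the estimate is 3000 nM, with an expected range from 1000 nM to 10000 nM.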

Compound 4, half-maximal inhibitory concentration: > 1000 nM
Compound 4: no number, only a limit (the forecaster's own chance of this, stated with the estimate: 85%); the middle value is on the limit's open side.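

Compound 4 also reports only a limit, so no step among compound 2, compound 3 and compound 4 can be read: the limit of > 1000 nM in this assay, at which 3 of the 4 values shown sit.

The compounds shown leave open where the true values of these three compounds lie, and so whether lengthening the chain changes inhibition at all in this assay.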